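Ethylsulfanyl in Place of Ethoxy on Compound 3

The source may report more compounds than this note shows. Statements on the series, on what has been measured and on what is new or still open speak of the compounds shown alone.

Measured compounds:
compound 1, `C=CC1C(=O)N(c2cc(OC)c(OC)c(OC)c2)C1c1ccc(OC)cc1`, 17 nM
compound 2, `CCSc1ccc(C2C(Oc3ccccc3)C(=O)N2c2cc(OC)c(OC)c(OC)c2)cc1`, 210 nM
compound 3, `C=CC1C(=O)N(c2cc(OC)c(OC)c(OC)c2)C1c1ccc(OCC)cc1`, 14 nM

In a functional assay on MCF7 cells (Homo sapiens) for inhibition, read by resazurin assay, with a stated time of 72 h (a lower number here means a stronger inhibitor, a higher number a weaker inhibitor), compound 3 gives the lowest of the three numbers shown. Its nearest neighbour is compound 1, which gives 17 nM, a gap within the scatter, so no order between them can be claimed. Compound 2 gives 210 nM, and this gap lies beyond the scatter.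

The new compound is compound 4, `C=CC1C(=O)N(c2cc(OC)c(OC)c(OC)c2)C1c1ccc(SCC)cc1`. It differs from compound 3 in one place: ethylsulfanyl in place of ethoxy on an aromatic carbon.

For the measured compounds named here, the only measured step, a 1.2-fold lower number from compound 1 to compound 3 (0.08 log units; within the scatter), changes the length of the chain on the oxygen and says nothing about exchanging oxygen for sulfur. Compound 2 carries an ethylsulfanyl group, but it differs from compound 3 in other places as well, so its value alone cannot be read as the effect of this exchange. Going by the values given here, with no step that bears directly on the change, the estimate for compound 4 stays close to compound 3, widened for the uncertainty. The step of a 2.1-fold higher number from compound 3 to compound 4 (0.33 log units; beyond the scatter) is expected to be small, within the scatter or only slightly beyond. Compound 4 is therefore estimated at 30 nM, with a range from 8 nM to 120 nM.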

Compound 4, half-maximal inhibitory concentration: 181 nM
Beside the measured number, compound 4's estimate is 6.0-fold (0.78 log units) below it; the measured number lies above the stated range.
By their numbers in this assay, from the lowest: compounds 3 and 1 (each within the scatter of the next); then compounds 4 and 2 (each within the scatter of the next).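

In this assay, this place on the ring proves sensitive to the atom linking the chain: a 13-fold higher number from compound 3 to compound 4 (1.11 log units; beyond the scatter), and an 11-fold higher number from compound 1 to compound 4 (1.03 log units; beyond the scatter), whereas a 1.2-fold lower number from compound 1 to compound 3 (0.08 log units; within the scatter). Among these compounds, then, methoxy and ethoxy cannot be told apart here, while ethylsulfanyl gives a clearly higher number than either. With ethylsulfanyl in place, a 1.2-fold lower number from compound 2 to compound 4 (0.06 log units; within the scatter), so in this pair vinyl and phenoxy on the saturated ring carbon cannot be told apart, although that pair alone cannot show whether the same holds with ethoxy.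

Nothing available here accounts for the effect of exchanging oxygen for sulfur. From the compounds shown here alone, it remains open how a methylsulfanyl group, a longer chain on sulfur or an amine at this place would read, and what phenoxy does alongside ethoxy.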